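The compounds below may be only part of what the source reports. "The series", "measured", "known", "first", "only" and "open" are said of these compounds alone.

Three compounds of this series have been measured:

compound 1, `O=C(Nc1cc2ncncc2cc1OCc1cccc(F)c1)Nc1cccc2ccccc12`, gives 1400 nM in a functional assay on GBM2 cells (Homo sapiens) for antiproliferative activity, read by WST assay, with a stated time of 72 h; a lower number here means a stronger inhibitor, a higher number a weaker inhibitor
compound 2, `O=C(Nc1cc2ncncc2cc1OCc1ccccc1Cl)Nc1cccc2ccccc12`, gives 2900 nM
compound 3, `O=C(Nc1cc2ncncc2cc1OCc1ccc(Cl)cc1)Nc1cccc2ccccc12`, gives 4500 nM

Compound 3 stands at the highest of the three numbers, that is, it is the weakest inhibitor of the set. Its nearest neighbour is compound 2, and the step of a 1.6-fold higher number from compound 2 to compound 3 (0.19 log units; within the scatter) lies within the scatter, so the two cannot be told apart. The step of a 3.2-fold higher number from compound 1 to compound 3 (0.51 log units; beyond the scatter) is beyond the scatter, and the step of a 2.1-fold higher number from compound 1 to compound 2 (0.32 log units; beyond the scatter) is also modest but real.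

Compound 4, `O=C(Nc1cc2ncncc2cc1OCc1ccc(F)cc1)Nc1cccc2ccccc12`, is not yet measured. It differs from compound 3 by one atom: fluoro in place of chloro on an aromatic carbon. The change keeps the substituent para to a large group and only swaps the halogen. Within the data shown here, none of the measured steps makes exactly this swap; the steps from compound 1 change both the halogen and its place, and the step from compound 2 to compound 3 moves a chloro group. These steps were all small to modest, so a step of similar or smaller size is expected, most likely toward a somewhat lower number, but a result within the scatter of compound 3 would not be surprising.

Compound 4 is expected to give 3000 nM, in the range 1500 nM to 6000 nM, which means an estimated step of a 1.5-fold lower number from compound 3 to compound 4 (0.18 log units; within the scatter).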

Compound 4, half-maximal inhibitory concentration: 4500 nM
For compound 4 the middle estimate is 1.5-fold (0.18 log units) below the measured one; the range from low to high includes it.
By their numbers in this assay, from the lowest: compound 1; then compounds 2, 3 and 4 (each within the scatter of the next).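

In this assay, the swap of chloro for fluoro on an aromatic carbon para to a large group gives no change at the digits printed from compound 3 to compound 4 (within the scatter), so at this position the identity of these two halogens makes no difference that can be detected. Among these compounds, compound 4 also gives the first comparison in which the halogen stays fluoro and only its place changes: a 3.2-fold higher number from compound 1 to compound 4 (0.51 log units; beyond the scatter), a modest step beyond the scatter, so the 3-fluorophenyl and 4-fluorophenyl groups can be told apart, whereas a 1.6-fold higher number from compound 2 to compound 4 (0.19 log units; within the scatter) leaves the 2-chlorophenyl and 4-fluorophenyl groups inseparable. No supporting data bear on why the halogen swap leaves the number unchanged or why the place of the fluoro group matters.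

The compounds shown leave open whether a 3-chlorophenyl group would match the 3-fluorophenyl group of compound 1, which would show whether the halogen is also interchangeable at that place. They also leave open what happens when the halogen at the 4-position gives way to something other than a halogen, such as a methoxy group, a nitrile or an amine.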